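From methylamino to methyl: compound 3 to compound 4

The source may hold more compounds than are shown below. What is called first, only, known or untested is meant among the compounds shown, and "the series" means these compounds.

Measured in an ADME assay on MRC5 cells (Homo sapiens), read by MTT assay, with a stated time of 72 h; a higher number here means a weaker inhibitor, a lower number a stronger inhibitor:
Compound 1 `CNc1ncnc2c1c(-c1cccs1)cn2[C@@H]1O[C@H](CO)[C@@H](O)[C@H]1O`: > 100000 nM (a limit)
Compound 2 `CNc1ncnc2c1c(-c1ccccc1)cn2[C@@H]1O[C@H](CO)[C@@H](O)[C@H]1O`: > 100000 nM (a limit)
Compound 3 `C#Cc1cn([C@@H]2O[C@H](CO)[C@@H](O)[C@H]2O)c2ncnc(NC)c12`: > 100000 nM (a limit)

Compound 3 stands at > 100000 nM, which is a limit and not a number. It shares this with the other two: the limit of > 100000 nM in this assay, at which 3 of the 3 values shown sit. Compound 4 `C#Cc1cn([C@@H]2O[C@H](CO)[C@@H](O)[C@H]2O)c2ncnc(C)c12` carries methyl in place of methylamino on an aromatic carbon. The measured steps all exchange a different group: a step that the two limits leave unreadable from compound 1 to compound 2, a step that the two limits leave unreadable from compound 1 to compound 3 and a step that the two limits leave unreadable from compound 2 to compound 3. None has a readable size, and none touches methylamino. In this assay, any readable change could only run toward a stronger inhibitor. The expected change, loosely estimated, is an at least 3.3-fold lower number from compound 3 to compound 4 (0.52 log units; beyond the scatter). Compound 4 is estimated at 30000 nM, with an expected range from 1000 nM to 100000 nM.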

Compound 4, half-maximal inhibitory concentration: 1440 nM
Compound 4: middle estimate off by 21-fold (1.32 log units), on the high side; measured number inside the range.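

Methyl in place of methylamino gives the first readable step in this assay: an at least 69-fold lower number from compound 3 to compound 4 (1.84 log units; beyond the scatter). The exchanges among thiophen-2-yl, phenyl and ethynyl could not be read, so this position is the first shown to move the number off the limit: the limit of > 100000 nM in this assay, at which 3 of the 4 values shown sit.

From the compounds shown here alone, whether this step depends on methyl itself or on the loss of methylamino stays open, and an amino, methoxy or ethyl group at this position would bear on that. Also open, going by these compounds, is whether methyl gives a similar step alongside thiophen-2-yl or phenyl instead of ethynyl.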